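The source may report more compounds than this note shows. Statements on the series, on what has been measured and on what is new or still open speak of the compounds shown alone.

Compound 1 `Cc1cc(C)cc(NC(=O)COc2cc(C)nc3ccccc23)c1` and compound 2 `Cc1cc(C)cc(NC(=O)COc2cc(C)nc3ccc(C(F)(F)F)cc23)c1` share one core; compound 2 carries trifluoromethyl on an aromatic carbon where compound 1 has hydrogen. In a physicochemical assay for solubility, in phosphate buffer, measured as kinetic solubility, with a stated time of 1 h, at pH 7.4 (on this read-out higher numbers stand for higher solubility and lower numbers for lower solubility), compound 1 gives 55000 nM, and compound 2 gives 10000 nM, the lower of the two numbers. That step, a 5.5-fold lower number from compound 1 to compound 2 (0.74 log units; beyond the scatter), is the only one measured so far. Compound 3 `Cc1cc(C)cc(NC(=O)COc2cc(C)nc3ccc(OCc4ccccc4)cc23)c1` differs from compound 2 by one change: benzyloxy in place of trifluoromethyl on an aromatic carbon. For the measured compounds named here, no measured step exchanges trifluoromethyl for another group, so the step from compound 1 to compound 2 bears on it only indirectly: a substituent entering at this carbon went with a modest drop. The group now entering is expected to leave the number near where it stands or move it somewhat lower, the step being estimated as a 2.0-fold lower number from compound 2 to compound 3 (0.30 log units; within the scatter). For compound 3 in this assay the expected value is 5000 nM, with a range from 1500 nM to 20000 nM.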

Compound 3, solubility: < 1000 nM
Compound 3: only a limit was reported; the forecaster's own chance of this, stated with the estimate: 15%; middle value at least 5.0-fold (0.69 log units) away from the limit.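

In this assay, for the compounds shown here, the aromatic carbon that carries trifluoromethyl in compound 2 proves more sensitive to the entering group than the single earlier step could show: benzyloxy gives an at least 10-fold lower number from compound 2 to compound 3 (1.00 log units; beyond the scatter). Measured against hydrogen, benzyloxy gives an at least 55-fold lower number from compound 1 to compound 3 (1.74 log units; beyond the scatter), a large step where trifluoromethyl gave only a modest one. Compound 3 stands at a limit of the assay and not at a number, so both new steps give only a bound on the size of the change: the limit of < 1000 nM in this assay, at which 1 of the 3 values shown sits.

On these data alone, how far compound 3 lies past that limit stays open. Also open, as far as these compounds go, is whether the drop goes with the six-membered aromatic ring of benzyloxy or with its oxygen; methoxy at this carbon would bear on that, and an amine or a carboxylic acid there would show whether the read-out can recover.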